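The source may hold more compounds than are shown below. What is called first, only, known or untested is meant among the compounds shown, and "the series" means these compounds.

Measured compounds:
- compound 1 `Cc1c(C(=O)Nc2c(F)cc(-c3cccc(F)c3)cc2F)nc2ccc(F)cc2c1O`: 28.8%
- compound 2 `CCOc1ccc2nc(C(=O)Nc3c(F)cc(-c4cccc(F)c4)cc3F)c(C)c(O)c2c1`: 16.3%

In a functional assay on A-375 cells (Homo sapiens) for antiproliferative activity, read by MTT assay, with a stated time of 24 h, tested at 33.33 ug/mL (on this read-out higher numbers stand for a stronger effect at the one concentration tested and lower numbers for a weaker effect), compound 2 stands lowest of the two numbers; the step of a number 12.5 percentage points lower from compound 1 to compound 2 (beyond the scatter) is the only one recorded. Compound 3 `Cc1c(C(=O)Nc2c(F)cc(-c3cccc(F)c3)cc2F)nc2ccc(C(F)(F)F)cc2c1O` differs from compound 2 by trifluoromethyl in place of ethoxy on an aromatic carbon. Going by the values given here, only the step from compound 1 to compound 2 bears on this change, as it alters the same aromatic carbon, and it was modest. Among the compounds with values here, no measured step with trifluoromethyl exists, so the direction is uncertain; a modest step upward, a number 5.7 percentage points higher from compound 2 to compound 3 (within the scatter), is expected. Compound 3 is therefore estimated at 22%, within 8% to 36%.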

Compound 3, a percentage reported as inhibition, at one concentration (the size of the read-out at that concentration, not a potency): 61.3%
Compound 3: the middle estimate sits 39.3 percentage points below what was measured; the measured number lies above the stated range.
By their numbers in this assay, from the lowest: compound 2; then compound 1; then compound 3.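

Going by these compounds alone, at this aromatic carbon of the shared core, the earlier compounds showed only a fall, whereas trifluoromethyl gives a number 45 percentage points higher from compound 2 to compound 3 (beyond the scatter) and a number 32.5 percentage points higher from compound 1 to compound 3 (beyond the scatter) in this assay at the one concentration tested. The position therefore allows a large rise over fluoro as well as over ethoxy, so fluoro does not mark the top of the range here. Nothing available explains this rise. Still open, going by these compounds, is how a chloro, a nitrile, an amine or a carboxylic acid would read at this carbon. With three groups, no trend across substituents can be drawn.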